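Estimating how well compound 3 is tolerated

The source may report more compounds than this note shows. Statements on the series, on what has been measured and on what is new or still open speak of the compounds shown alone.

In an ADME assay on RAW264.7 cells (Mus musculus) for cytotoxicity, read by MTT assay, with a stated time of 24 h (a lower number here means that less compound is tolerated, a higher number that more compound is tolerated), compound 1 (`CC/C=C\C[C@H]1C(=O)C=C[C@H]1CC(=O)OCCCC`) gives 31 uM and stands level with compound 2 (`CC/C=C\C[C@H]1C(=O)C=C[C@H]1CC(=O)OCc1ccccc1`) at 31 uM on these numbers. Among the measured compounds shown here, compound 3 (`CC/C=C\C[C@H]1C(=O)C=C[C@H]1CC(=O)OCCOCCOCCOC`) has no measurement yet. Its difference from compound 1 is 2-(2-methoxyethoxy)ethoxy in place of ethyl on a saturated chain carbon, two bonds along the chain from an oxygen next to a carbonyl group and amounts to 2-(2-methoxyethoxy)ethoxy in place of ethyl on a saturated chain carbon, two bonds along the chain from an oxygen next to a carbonyl group. For the measured compounds named here, the only measured step that bears on this, phenyl in place of propyl, gives no change at the digits printed from compound 1 to compound 2 (within the scatter) and is thin evidence. The expected outcome is therefore a 1.1-fold higher number from compound 1 to compound 3 (0.05 log units; within the scatter) with no shift beyond the scatter. Compound 3 is estimated at 35 uM and expected to fall from 15 uM to 80 uM when measured.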

Compound 3, half-maximal toxic concentration: 163 uM
Compound 3: the middle estimate sits 4.7-fold (0.67 log units) below what was measured, outside the stated range (above it).
By their numbers in this assay, from the lowest: compounds 1 and 2 (each within the scatter of the next); then compound 3.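

In this assay, 2-(2-methoxyethoxy)ethoxy in place of ethyl on a saturated chain carbon, two bonds along the chain from an oxygen next to a carbonyl group, gives a 5.3-fold higher number from compound 1 to compound 3 (0.72 log units; beyond the scatter). This position can therefore change how much compound the cells tolerate, which the earlier step, no change at the digits printed from compound 1 to compound 2 (within the scatter), did not show. Nothing available here accounts for the rise. Still open, on these data alone, is whether the oxygens or the length of the chain matter. A longer all-carbon chain or an amine at the chain end would help separate the two.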